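A few compounds are considered here, and "the series" means these few. Any claim that something is new, unique, unknown or untested is made for them only; others in the source may bear on it.

In a functional assay on A-431 cells (Homo sapiens) for inhibition, read by MTT assay, with a stated time of 72 h (a higher number here means a weaker inhibitor, a lower number a stronger inhibitor), three compounds that share one core have been measured. Compound 1 `CC/C=C/C(=O)Nc1cccc(Oc2nc(Nc3cccc(OC)c3)nc3ccsc23)c1` gives 29200 nM. Compound 2 `COc1cccc(Nc2nc(Oc3cccc(NC(=O)/C=C/C(C)C)c3)c3sccc3n2)c1` gives 23400 nM. Compound 3 `CCC/C=C/C(=O)Nc1cccc(Oc2nc(Nc3cccc(OC)c3)nc3ccsc23)c1` gives 8090 nM, the lowest of the three numbers and so the strongest inhibitor among them: the step of a 3.6-fold lower number from compound 1 to compound 3 (0.56 log units; beyond the scatter) and the step of a 2.9-fold lower number from compound 2 to compound 3 (0.46 log units; beyond the scatter) both lie beyond the scatter, while the step of a 1.2-fold lower number from compound 1 to compound 2 (0.10 log units; within the scatter) lies within it. All three of these steps alter only the chain attached to the amide. Compound 4 `CCC/C=C/C(=O)Nc1cccc(Oc2nc(Nc3cccc(C#N)c3)nc3ccsc23)c1` differs from compound 3 in another place: cyano in place of methoxy on an aromatic carbon. Going by the values given here, no measured step touches this part of the molecule, so nothing among the three measured compounds shows how this assay responds to such a change. The expectation for compound 4 therefore rests on compound 3 alone, with the step of a 1.0-fold lower number from compound 3 to compound 4 (0.00 log units; within the scatter) expected to be small in either direction and the uncertainty wide. Compound 4 is estimated at 8000 nM, with a range from 2000 nM to 32000 nM.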

Compound 4, half-maximal inhibitory concentration: 20400 nM
For compound 4 the middle estimate is 2.6-fold (0.41 log units) below the measured one; low and high end bracket the measured number.
By their numbers in this assay, from the lowest: compound 3; then compounds 4, 2 and 1 (each within the scatter of the next).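

In this assay, going by these compounds alone, replacing methoxy with cyano on this aromatic carbon gives a 2.5-fold higher number from compound 3 to compound 4 (0.40 log units; beyond the scatter), so a modest change beyond the scatter can arise outside the chain on the amide, the only part varied among the earlier compounds. Methoxy and cyano match in heavy atoms and hydrogen-bond acceptors and neither carries a net charge, so these counts do not separate the two groups, even though the numbers differ. No measurement at hand explains why the number rises with this change.

The cyano group is shown only with the amide chain of compound 3, so whether the step would be similar with the chains of compound 1 or compound 2 remains open. From the compounds shown here alone, how an amine, a hydroxyl group or a chlorine atom on this carbon would read also remains open.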